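Pyridin-2-yl for chloro on the oxazole of compound 1

A few compounds are considered here, and "the series" means these few. Any claim that something is new, unique, unknown or untested is made for them only; others in the source may bear on it.

For the measured compounds named here, compound 1 `O=C(CCCCCCc1ccccc1)c1nc(Cl)co1` is the only member of the series with a number rather than a limit: in an assay on HEK-293T cells for inhibition of diacylglycerol lipase-alpha (Homo sapiens), read by colorimetric assay (a higher number here means a weaker inhibitor, a lower number a stronger inhibitor), compound 1 gives 2400 nM. Compound 2 `O=C(CCCCCCc1ccccc1)c1ncc(Cl)o1` gives only a limit of the assay, > 10000 nM. Compound 3 `CSc1cnc(C(=O)CCCCCCc2ccccc2)o1` likewise gives only a limit, > 10000 nM. Both steps away from compound 1 thus read as an at least 4.1-fold higher number from compound 1 to compound 2 (0.61 log units; beyond the scatter) and an at least 4.1-fold higher number from compound 1 to compound 3 (0.61 log units; beyond the scatter), each ending at the limit of > 10000 nM in this assay, at which 2 of the 3 values shown sit. The step between compound 2 and compound 3 is a step that the two limits leave unreadable from compound 2 to compound 3.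

Compound 4 `O=C(CCCCCCc1ccccc1)c1nc(-c2ccccn2)co1` differs from compound 1 in one place: pyridin-2-yl in place of chloro on an aromatic carbon. Going by the values given here, no measured step swaps a group at this position while leaving the rest unchanged; the two measured steps move or change the substituent and both weaken beyond the scatter. Compound 4 is therefore expected to be weaker than compound 1, with the step estimated as a 1.9-fold higher number from compound 1 to compound 4 (0.27 log units; within the scatter). The estimate for compound 4 in this assay is 4500 nM, within 1500 nM to 13000 nM.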

Compound 4, half-maximal inhibitory concentration: > 10000 nM
Compound 4: no number, only a limit; the forecaster's own chance of this, stated with the estimate: 30%; middle value at least 2.2-fold (0.34 log units) from the limit.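

Replacing chloro with pyridin-2-yl on the aromatic carbon next to the ring nitrogen gives an at least 4.1-fold higher number from compound 1 to compound 4 (0.61 log units; beyond the scatter). For the compounds shown here, compounds 2 and 3 lose the group at this carbon and carry their substituent elsewhere on the ring, whereas compound 4 keeps a group here, so in this assay occupying this place does not by itself preserve a readable inhibition value, and chloro remains the only group here with a number. The step ends at a limit of the assay, not at a number: the limit of > 10000 nM in this assay, at which 3 of the 4 values shown sit.

On these data alone, how far compound 4 lies from compound 1 stays open, and the step between compound 2 and compound 3 cannot be read. Also open, as far as these compounds go, is whether a methyl group, a methoxy group, an amine or an unsubstituted phenyl ring on this carbon would give a number in this assay.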